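Lengthening the chain from compound 2 to compound 3

The compounds below may be only part of what the source reports. "The series", "measured", "known", "first", "only" and "open" are said of these compounds alone.

In a functional assay on KG-1 cells (Homo sapiens) for inhibition, read by MTT assay, with a stated time of 48 h (a higher number here means a weaker inhibitor, a lower number a stronger inhibitor), compound 1 (`O=C(O)c1ccc2c(c1)no[n+]2[O-]`) has the entry "not determined" (no result reported) and so gives no number, while compound 2 (`O=C(CCCCOC(=O)c1ccc2c(c1)no[n+]2[O-])NO`) reads 8190 nM as the only number shown. Compound 3 (`O=C(CCCCCCOC(=O)c1ccc2c(c1)no[n+]2[O-])NO`) carries the change 2-(hydroxycarbamoyl)ethyl in place of hydroxycarbamoyl on a saturated chain carbon, four bonds along the chain from an oxygen next to a carbonyl group with 2-(hydroxycarbamoyl)ethyl in place of hydroxycarbamoyl on a saturated chain carbon. Within the data shown here, no measured step exists to guide this change, so the expectation rests on the structural change alone. A modest move toward a stronger inhibitor is expected, with an estimated 2.7-fold lower number from compound 2 to compound 3 (0.44 log units; beyond the scatter) in this assay as its size. Compound 3 is estimated at 3000 nM with an expected range from 800 nM to 10000 nM in that measurement.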

Compound 3, half-maximal inhibitory concentration: 370 nM
Compound 3: the middle estimate sits 8.1-fold (0.91 log units) above what was measured; the whole stated range lies above it.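

Putting 2-(hydroxycarbamoyl)ethyl in place of hydroxycarbamoyl on a saturated chain carbon, four bonds along the chain from an oxygen next to a carbonyl group, gives a 22-fold lower number from compound 2 to compound 3 (1.35 log units; beyond the scatter) in this assay and so shows that activity at this position depends strongly on chain length. Compound 2 alone, as a single number, could not show this. Nothing available here accounts for the size of the step.

Going by these compounds, whether a longer chain than that of compound 3 would lower the number further remains open. So does whether a carboxylic acid at the chain end in place of the hydroxycarbamoyl group would keep the gain.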